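This account rests on a few compounds, and the source may have more. Where it says the series, first, only, none or still open, it means among the compounds named here.

Compound 1 `COc1cc([C@H]2C[C@@]2(CO)C(=O)NCc2ccc(C)cc2)cc(OC)c1OC` and compound 2 `CCOC(=O)[C@@]1(C(=O)NCc2ccc(C)cc2)C[C@H]1c1cc(OC)c(OC)c(OC)c1` share one core and were both tested in a functional assay on K562 cells (Homo sapiens) for cytotoxicity, read by MTT assay, with a stated time of 48 h; a lower number here means a stronger inhibitor, a higher number a weaker inhibitor. In this assay compound 1 gives only a limit, > 100000 nM. Compound 2 likewise gives only a limit in this assay, > 100000 nM. Compound 2 therefore stands at the limit of > 100000 nM in this assay, at which 2 of the 2 values shown sit, with no numbered value to build on. Compound 3 `COc1cc([C@@H]2C[C@@]2(CO)C(=O)NCc2ccc(C)cc2)cc(OC)c1OC` is not yet measured; it differs from compound 2 by hydroxymethyl in place of ethoxycarbonyl on a saturated ring carbon. The expected step that the limit leaves unreadable from compound 2 to compound 3 is none beyond the scatter. Compound 3 is expected to sit at 150000 nM, in a range from 50000 nM to 500000 nM, most likely again only as a limit in this assay.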

Compound 3, half-maximal inhibitory concentration: > 100000 nM
Compound 3 gave a limit, no number (the forecaster's own chance of this, stated with the estimate: 80%); the middle value is on the limit's open side.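

Among these compounds, compound 1, compound 2 and compound 3 can be compared in this assay only through limits, so no step between them can be read: the limit of > 100000 nM in this assay, at which 3 of the 3 values shown sit. The compounds shown leave open how strongly any of them acts on these cells, and whether the configuration separating compound 1 from compound 3 matters.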